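The compounds below may be only part of what the source reports. "The series", "measured", "known", "first", "only" and "open" are said of these compounds alone.

Measured so far:

Compound 1, `CCC(C)Sc1nc2c(cc(-c3ccc(C)cc3)n2-c2ccccc2)c(=N)s1`: 2%
Compound 2, `CCC(C)Sc1nc2c(cc(-c3ccc(Br)cc3)n2-c2ccccc2)c(=N)s1`: 70%
Compound 3, `CCn1c(=S)[nH]c2c(cc(-c3ccc(C)cc3)n2-c2ccccc2)c1=N`: 60%

All three were tested in a functional assay on the whole organism for inhibition, with Rattus norvegicus as the target, read by ELISA, with stated times of 30 min and 6 h, at a dose of 30 mg/kg by the oral route; a lower number here means less inhibition, a higher number more inhibition at the dose given (going by the name of the read-out). Compound 1 and compound 2 share one core and differ in a single place: bromo in place of methyl on an aromatic carbon. That change made a step of a number 68 percentage points higher from compound 1 to compound 2 (beyond the scatter), so compound 2 sits far above compound 1 in this assay. Compound 3 has a different core; the difference between the two cores is not broken down here, and compound 3 gives a value within the usual scatter of compound 2, while standing well above compound 1.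

Compound 4, `CCn1c(=S)[nH]c2c(cc(-c3ccc(Br)cc3)n2-c2ccccc2)c1=N`, has not yet been measured. It is built from compound 3 by the same change that turns compound 1 into compound 2: bromo in place of methyl on an aromatic carbon, at the same place on the same kind of ring. Within the data shown here, whether the change behaves the same on the core of compound 3 as it did on the core of compound 1 is not known from the data; only one measured pair shows it. Still, the step from compound 3 to compound 4 is expected to go upward, estimated at a number 22 percentage points higher from compound 3 to compound 4 (beyond the scatter), because compound 1 to compound 2 gave a number 68 percentage points higher from compound 1 to compound 2 (beyond the scatter) and because compound 3 already starts from 60%, leaving less room for the number to rise further in this assay. Compound 4 is therefore expected to give about 82% in this assay, most likely between 58% and 98%.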

Compound 4, a percentage reported as inhibition, in the whole organism at one dose (the size of the read-out at that dose, not a potency): 80%
The estimate for compound 4 lay 2 percentage points above the measured number; measured number inside the range.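

On the core of compound 3, the change from 4-methylphenyl to 4-bromophenyl again moves the result upward in this assay, with a number 20 percentage points higher from compound 3 to compound 4 (beyond the scatter). The direction of the change therefore carries over from one core to the other, but its size does not, as the two steps side by side make clear: the same change on two cores in this assay, a number 68 percentage points higher (beyond the scatter) from compound 1 to compound 2 and a number 20 percentage points higher (beyond the scatter) from compound 3 to compound 4, 48 percentage points apart, beyond the scatter of two such steps. Among these compounds, these two pairs show only that the bromo compound reads higher than its methyl partner on both cores; they do not show that the same would happen on a third core, they do not explain why the size differs, and a reading at one dose says nothing about potency.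

The compounds shown leave open how other groups would behave at this same place on the ring, such as chloro, methoxy, an amine or a carboxylic acid, and whether any of them would match bromo on both cores. They also leave open whether a longer chain in place of the ethyl group of compound 4 would keep, raise or lower the inhibition seen at this dose.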